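The compounds below may be only part of what the source reports. "The series", "measured", "known", "first", "only" and "open" are said of these compounds alone.

Working notes on the series. Compound 1 `Clc1ccccc1CSc1nnc(-c2ccncc2)n1-c1ccccc1` and compound 2 `O=C(CSc1nnc(-c2ccncc2)n1-c1ccccc1)N/N=C/c1ccc([N+](=O)[O-])cc1` are the two members that return a number in a functional assay on HCT-116 cells (Homo sapiens) for inhibition, read by MTT assay, with a stated time of 48 h; a lower number here means a stronger inhibitor, a higher number a weaker inhibitor: compound 1 gives 13900 nM, and compound 2 gives 10200 nM. Compound 3 `O=C(CSc1nnc(-c2ccncc2)n1-c1ccccc1)N/N=C/c1ccc(O)cc1` does not return a number; in this assay compound 3 reaches only a limit, > 50000 nM. Among the measured compounds shown here, the one single-point step measured so far, an at least 4.9-fold higher number from compound 2 to compound 3 (0.69 log units; beyond the scatter), is therefore known only as a lower bound on its size, since it ends at the limit of > 50000 nM in this assay, at which 1 of the 3 values shown sits. Compound 3 thus stands at the bottom of the numbers shown, with its true value unknown beyond the limit.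

Compound 4 `O=C(CSc1nnc(-c2ccncc2)n1-c1ccccc1)N/N=C/c1ccc(Cl)cc1` differs from compound 3 by chloro in place of hydroxy on an aromatic carbon. For the measured compounds named here, the only measured step that bears on this position is an at least 4.9-fold higher number from compound 2 to compound 3 (0.69 log units; beyond the scatter), which shows that the group on that aromatic carbon moves the number by an at least modest amount in this assay. Chloro is a third group at the same place, neither the nitro of compound 2 nor the hydroxy of compound 3, so the expectation is a number between those two, closer to a measurable value than to the limit. Compound 4 is expected at 15000 nM, within 5000 nM to 50000 nM. This estimate means a step of an at least 3.3-fold lower number from compound 3 to compound 4 (0.52 log units; beyond the scatter), a lower number expected in this assay.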

Compound 4, half-maximal inhibitory concentration: 5740 nM
Beside the measured number, compound 4's estimate is 2.6-fold (0.42 log units) above it; the range from low to high includes it.
By their numbers in this assay, from the lowest: compounds 4, 2 and 1 (each within the scatter of the next, the first and the last beyond it). At a limit, above all of these: compound 3.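

In this assay the change from 4-hydroxyphenyl to 4-chlorophenyl gives an at least 8.7-fold lower number from compound 3 to compound 4 (0.94 log units; beyond the scatter), so a group other than nitro on this aromatic carbon also returns a measurable number. Set against nitro, chloro gives a 1.8-fold lower number from compound 2 to compound 4 (0.25 log units; within the scatter), which leaves the two groups unseparated on these data and makes hydroxy the only one of the three groups at this place that sits apart from the others. The size of both steps involving hydroxy remains a lower bound only, as compound 3 stands at a limit, not a number: the limit of > 50000 nM in this assay, at which 1 of the 4 values shown sits.

Going by these compounds, it stays open whether compound 3 is an isolated case among groups at this place, and an amine, a methoxy group or a carboxylic acid on the same aromatic carbon would test that. Also open, on these data alone, is how chloro would read on the other carbons of that six-membered aromatic ring, since every comparison so far concerns a single position, the one para to a large group.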